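Notes on compound 4, a fluoro step from compound 1

This account rests on a few compounds, and the source may have more. Where it says the series, first, only, none or still open, it means among the compounds named here.

Among the measured compounds shown here, compound 1 `COc1ccc(C(=O)Nc2cccc(-c3oc4cc(-c5ccc(F)cc5)ccc4c(=O)c3O)c2)cc1` gives 8700 nM in a functional assay on A549 cells (Homo sapiens) for antiproliferative activity, read by CCK-8 assay, with a stated time of 72 h (on this read-out lower numbers stand for stronger inhibition and higher numbers for weaker inhibition), the second highest of the three numbers so far. Compound 2 `Cc1ccc(C(=O)Nc2cccc(-c3oc4cc(-c5ccc(F)cc5)ccc4c(=O)c3O)c2)cc1` gives 6910 nM and compound 3 `CCc1ccc(C(=O)Nc2cccc(-c3oc4cc(-c5ccc(F)cc5)ccc4c(=O)c3O)c2)cc1` gives 18500 nM. The steps of a 1.3-fold lower number from compound 1 to compound 2 (0.10 log units; within the scatter) and a 2.1-fold higher number from compound 1 to compound 3 (0.33 log units; beyond the scatter) exchange the methoxy group itself, and a 2.7-fold higher number from compound 2 to compound 3 (0.43 log units; beyond the scatter) lengthens the chain there. Compound 4 `COc1ccc(C(=O)Nc2cccc(-c3oc4cc(-c5ccc(F)cc5)ccc4c(=O)c3O)c2)c(F)c1` differs from compound 1 by fluoro in place of hydrogen on an aromatic carbon. For the measured compounds named here, no measured step bears directly on this change; the three known steps only swap methoxy, methyl and ethyl. The two steps beyond the scatter were modest, so an expected step of similar size or smaller is assumed: a 1.1-fold lower number from compound 1 to compound 4 (0.04 log units; within the scatter) is expected, with no clear direction. Compound 4 is therefore estimated at 8000 nM, between 3500 nM and 20000 nM.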

Compound 4, half-maximal inhibitory concentration: 40000 nM
Beside the measured number, compound 4's estimate is 5.0-fold (0.70 log units) below it; the whole stated range lies below it.
By their numbers in this assay, from the lowest: compounds 2 and 1 (each within the scatter of the next); then compound 3; then compound 4.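

Fluoro in place of hydrogen, ortho to a large group, is the first change that keeps the methoxy group, and it gives a larger step than any exchange of methoxy, methyl or ethyl (a 4.6-fold higher number from compound 1 to compound 4 (0.66 log units; beyond the scatter)). The 2-fluoro-4-methoxyphenyl group also gives higher numbers than 4-methylphenyl (a 5.8-fold higher number from compound 2 to compound 4 (0.76 log units; beyond the scatter)) and 4-ethylphenyl (a 2.2-fold higher number from compound 3 to compound 4 (0.33 log units; beyond the scatter)). No data at hand account for this loss.

As far as these compounds go, whether it belongs to fluoro itself or to this carbon remains open. Chloro or an amine on the same carbon would help separate the two.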